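The compounds below may be only part of what the source reports. "The series", "measured", "known", "first", "only" and "open" are said of these compounds alone.

In an in vitro ADME assay on microsomes from liver (Mus musculus) for pharmacokinetics, read by LC-MS, with a stated time of 10 min, tested at 1 uM (a higher number here means faster removal of the compound, a lower number slower removal), three compounds sharing one core have been measured. Compound 1 (`CN1C[C@H](C(=O)Nc2ccccc2F)[C@@H](c2ccc(/C=C/C(=O)Nc3ccccc3N)cc2)C1`) shows 67 mL/min/kg as its clearance, compound 2 (`CN1C[C@H](C(=O)Nc2ccc(F)c(Br)c2)[C@@H](c2ccc(/C=C/C(=O)Nc3ccccc3N)cc2)C1`) shows 43 mL/min/kg and compound 3 (`CN1C[C@H](C(=O)Nc2ccc(Cl)cc2F)[C@@H](c2ccc(/C=C/C(=O)Nc3ccccc3N)cc2)C1`) shows 43 mL/min/kg as its clearance too. Compound 3 therefore stands level with compound 2, and its gap to compound 1 lies within the scatter.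

Compound 4 (`CN1C[C@H](C(=O)Nc2cccnc2)[C@@H](c2ccc(/C=C/C(=O)Nc3ccccc3N)cc2)C1`) carries pyridin-3-yl in place of 4-chloro-2-fluorophenyl on an amide-type nitrogen and has not yet been measured. Three measured steps alter the group at that same place, namely a 1.6-fold lower number from compound 1 to compound 2 (0.19 log units; within the scatter) along with a 1.6-fold lower number from compound 1 to compound 3 (0.19 log units; within the scatter) and no change at the digits printed from compound 2 to compound 3 (within the scatter) and none of them goes beyond the scatter. On that evidence, no step beyond the scatter is expected in this assay for the new change. Going by the values given here, no measured compound has a ring with a hetero atom at this place, so the range must stay wide. The estimated step is a 1.2-fold higher number from compound 3 to compound 4 (0.07 log units; within the scatter) and it would remain within the scatter. Compound 4 is expected at 50 mL/min/kg with an estimated range from 25 mL/min/kg to 90 mL/min/kg around that figure.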

Compound 4, clearance: 41 mL/min/kg
Compound 4: middle estimate off by 1.2-fold (0.09 log units), on the high side; measured number inside the range.
By their numbers in this assay, from the lowest: compounds 4, 2, 3 and 1 (each within the scatter of the next).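

In this assay, the first ring with a hetero atom at this amide-type nitrogen gives a 1.0-fold lower number from compound 3 to compound 4 (0.02 log units; within the scatter) and a 1.0-fold lower number from compound 2 to compound 4 (0.02 log units; within the scatter) and a 1.6-fold lower number from compound 1 to compound 4 (0.21 log units; within the scatter) and so adds no step beyond the scatter. This position has therefore now taken a pyridin-3-yl group, with its ring nitrogen and hydrogen-bond acceptor and without any halogen, and clearance stays within the scatter of all three halogenated phenyl compounds. Nothing measured here gives a reason for this flat result.

All four groups at this place are six-membered aromatic rings, so the compounds shown leave open whether a non-aromatic group, such as cyclohexyl or a longer alkyl chain, would behave the same way. They also leave open whether a carboxylic acid or an amine on the ring would produce a step beyond the scatter.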